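Bromo in Place of Chloro: Expectation for Compound 3

The compounds below may be only part of what the source reports. "The series", "measured", "known", "first", "only" and "open" are said of these compounds alone.

Measured compounds:
compound 1, `NC(=S)N/N=C1/C(=O)N(CN2CCN(c3ccnc4cc(Cl)ccc34)CC2)c2cc(Br)ccc21`, 11400 nM
compound 2, `NC(=S)N/N=C1/C(=O)N(CN2CCN(c3ccnc4cc(C(F)(F)F)ccc34)CC2)c2cc(Cl)ccc21`, 24600 nM

In a functional assay on MCF7 cells (Homo sapiens) for cytotoxicity, read by sulforhodamine B assay, with a stated time of 48 h (a higher number here means a weaker inhibitor of growth, a lower number a stronger inhibitor of growth), compound 1 gives 11400 nM, and compound 2 gives 24600 nM. Compound 2 stands at the highest number of the two, and its gap to compound 1 lies beyond the usual scatter. Compound 1 and compound 2 differ in two places, so the two values alone do not show which change carries that gap.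

Compound 3, `NC(=S)N/N=C1/C(=O)N(CN2CCN(c3ccnc4cc(C(F)(F)F)ccc34)CC2)c2cc(Br)ccc21`, differs from compound 2 by bromo in place of chloro on an aromatic carbon. Within the data shown here, no pair of measured compounds differs by this change alone, so there is no measured step to lean on. Compound 1 carries bromo at that place, but it also differs from compound 2 elsewhere, so its value cannot be attributed to bromo. The step from compound 2 to compound 3 is expected to be small, a 1.3-fold lower number from compound 2 to compound 3 (0.11 log units; within the scatter), within or near the scatter. Compound 3 is estimated at 19000 nM, with a range from 7000 nM to 50000 nM.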

Compound 3, concentration for 50% growth inhibition: 35500 nM
Compound 3: middle estimate off by 1.9-fold (0.27 log units), on the low side; the range from low to high includes it.
By their numbers in this assay, from the lowest: compound 1; then compounds 2 and 3 (each within the scatter of the next).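

In this assay, bromo in place of chloro on an aromatic carbon, with trifluoromethyl kept on the other part of the molecule, gives a 1.4-fold higher number from compound 2 to compound 3 (0.16 log units; within the scatter) and so does not separate the two halogens at this place. With bromo kept on that carbon, trifluoromethyl in place of chloro on the other part gives a 3.1-fold higher number from compound 1 to compound 3 (0.49 log units; beyond the scatter) and is the only single change shown here that lies beyond the scatter. Nothing measured here accounts for either step.

The compounds shown leave open whether a methoxy group, an amine or plain hydrogen in place of the halogen would shift the number. They also leave open whether the trifluoromethyl step would hold with chloro instead of bromo on the aromatic carbon.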